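Swapping a hydroxyl bearing chain for a carboxylic acid

The source may report more compounds than this note shows. Statements on the series, on what has been measured and on what is new or still open speak of the compounds shown alone.

Of the compounds shown here, three sharing one core have been tested in an ADME assay on cells (spleen, Mus musculus, strain C57BL/6) for inhibition, read by flow cytometry and propidium iodide staining, with a stated time of 24 h, at 37 degrees C; on this read-out lower numbers stand for an effect already at smaller amounts and higher numbers for an effect only at larger amounts of compound. Compound 1 `CCC(O)Cc1cn(CC(=O)NCc2ccccc2)nn1` gives 630 uM. Compound 2 `O=C(Cn1cc(CCCCO)nn1)NCc1ccccc1` gives 1700 uM, and compound 3 `CC(C)(O)c1cn(CC(=O)NCc2ccccc2)nn1` gives 1600 uM. Compound 3 thus stands second highest of the three, with compound 2 within the scatter of it, and the step of a 2.5-fold higher number from compound 1 to compound 3 (0.40 log units; beyond the scatter) placing compound 1 well apart. The step of a 1.1-fold lower number from compound 2 to compound 3 (0.03 log units; within the scatter) shows that two different hydroxyl-bearing groups on the aromatic carbon give indistinguishable numbers, while the step of a 2.7-fold higher number from compound 1 to compound 2 (0.43 log units; beyond the scatter) shows that moving the hydroxyl along the chain matters only modestly.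

Compound 4 `O=C(O)CCc1cn(CC(=O)NCc2ccccc2)nn1` differs from compound 3 by 2-carboxyethyl in place of 1-hydroxy-1-methylethyl on an aromatic carbon. For the measured compounds named here, no measured step replaces a hydroxyl group with a carboxylic acid, so the measured steps bear on it only loosely: they all change the group on this same aromatic carbon and none moved the number beyond a modest amount. A small change in this assay is therefore expected, most likely toward a higher number, with a 1.2-fold higher number from compound 3 to compound 4 (0.07 log units; within the scatter) as the estimated step. Compound 4 is expected to give about 1900 uM, with a range from 800 uM to 4500 uM.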

Compound 4, concentration for half-maximal effect: 1420 uM
Compound 4: the middle estimate sits 1.3-fold (0.13 log units) above what was measured; the range from low to high includes it.
By their numbers in this assay, from the lowest: compound 1; then compounds 4, 3 and 2 (each within the scatter of the next).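

In this assay the step to 2-carboxyethyl gives a 1.1-fold lower number from compound 3 to compound 4 (0.05 log units; within the scatter) and so stays level with the tertiary alcohol group, and the comparison with the 4-hydroxybutyl compound gives a 1.2-fold lower number from compound 2 to compound 4 (0.08 log units; within the scatter) and is also level. For the compounds shown here, compounds 1, 2 and 3 all carry a hydroxyl on the chain, so compound 4 is the first of this set to show that a hydroxyl is not needed on this aromatic carbon for a number at the level of compounds 2 and 3. Compound 1 remains the one apart, with a 2.3-fold higher number from compound 1 to compound 4 (0.35 log units; beyond the scatter) as its distance from the new compound, and the data in hand offer no measured explanation for this.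

Still open, as far as these compounds go, is whether a chain with no oxygen at all, such as plain butyl, or a primary amine on a propyl chain would sit with compounds 2, 3 and 4 or with compound 1. A carboxylic acid on a longer chain, or one placed directly on the aromatic carbon, would show whether the level seen for compound 4 depends on the length of the chain.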